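The source may report more compounds than this note shows. Statements on the series, on what has been measured and on what is new or still open speak of the compounds shown alone.

Compound 1 `CCCCCCCCNC(=O)[C@@H](NC(=O)c1cccs1)[C@@H](C)O` and compound 2 `CCCCCCCCNC(=O)[C@@H](NC(=O)c1cc2ccccc2o1)[C@@H](C)O` share one core, and compound 3 `CCCCCCCCCCCCNC(=O)[C@@H](NC(=O)c1cccs1)[C@@H](C)O` and compound 4 `CCCCCCCCCCCCNC(=O)[C@@H](NC(=O)c1cc2ccccc2o1)[C@@H](C)O` share another; the two cores differ as butyl in place of hydrogen on a saturated chain carbon, eight bonds along the chain from an amide-type nitrogen. In a functional assay on A-431 cells (Homo sapiens) for cytotoxicity, read by MTT assay, with a stated time of 48 h (a higher number here means a weaker inhibitor, a lower number a stronger inhibitor), compound 1 gives 32200 nM, compound 2 gives 52700 nM and compound 3 gives 16600 nM. The move a 1.9-fold lower number from compound 1 to compound 3 (0.29 log units; within the scatter) was thus small. The change 1-benzofuran-2-yl in place of thiophen-2-yl on a carbonyl carbon produced a 1.6-fold higher number from compound 1 to compound 2 (0.21 log units; within the scatter). The same change, (1-benzofuran-2-yl in place of thiophen-2-yl on a carbonyl carbon), is now made on the core of compound 3, and compound 4 has not yet been measured in this assay. Because the earlier step was a 1.6-fold higher number from compound 1 to compound 2 (0.21 log units; within the scatter), a step of about the same size is expected from compound 3 to compound 4, namely a 1.6-fold higher number from compound 3 to compound 4 (0.19 log units; within the scatter). Compound 4 is therefore estimated at 26000 nM, most likely between 12000 nM and 55000 nM.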

Compound 4, half-maximal inhibitory concentration: 20000 nM
For compound 4 the middle estimate is 1.3-fold (0.11 log units) above the measured one, within the range that was stated.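

In this assay, 1-benzofuran-2-yl in place of thiophen-2-yl gave a 1.2-fold higher number from compound 3 to compound 4 (0.08 log units; within the scatter), and this step matches the earlier one on the other core: the same change on two cores in this assay, a 1.6-fold higher number (0.21 log units; within the scatter) from compound 1 to compound 2 and a 1.2-fold higher number (0.08 log units; within the scatter) from compound 3 to compound 4, 1.4-fold (0.13 log units) apart, within the scatter of two such steps. Butyl in place of hydrogen on the saturated chain gave a 2.6-fold lower number from compound 2 to compound 4 (0.42 log units; beyond the scatter), and this change also carried over between the cores: the same change on two cores in this assay, a 1.9-fold lower number (0.29 log units; within the scatter) from compound 1 to compound 3 and a 2.6-fold lower number (0.42 log units; beyond the scatter) from compound 2 to compound 4, 1.4-fold (0.13 log units) apart, within the scatter of two such steps. Across these four compounds, the two changes show no sign of depending on each other, but both ring-swap steps lie within the scatter, so the data do not show that this swap itself alters the read-out, and two cores establish no general rule.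

As far as these compounds go, whether a longer chain would continue the trend remains open. So does whether a phenyl group in place of thiophen-2-yl on the carbonyl carbon would carry over between cores in the same way.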